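From Chloro to Bromo: Expected Cytotoxicity of Compound 4

The source may report more compounds than this note shows. Statements on the series, on what has been measured and on what is new or still open speak of the compounds shown alone.

compound 1 `N#Cc1c(N)cccc1Sc1ccccc1`: 168000 nM
compound 2 `Cc1ccccc1Sc1cccc(N)c1C#N`: > 40000 nM (a limit)
compound 3 `N#Cc1c(N)cccc1Sc1ccccc1Cl`: 33000 nM

In a functional assay on MT4 cells (Homo sapiens) for cytotoxicity (on this read-out lower numbers stand for stronger inhibition and higher numbers for weaker inhibition), compound 1 gives 168000 nM. Compound 2 gives only > 40000 nM, which is a limit of this assay and not a number. Compound 3 gives 33000 nM in this assay and stands lowest of the two numbers shown; the nearest number is that of compound 1, separated by a 5.1-fold lower number from compound 1 to compound 3 (0.71 log units; beyond the scatter). The step of an at least 1.2-fold lower number from compound 2 to compound 3 (0.08 log units; that floor lies within the scatter) is read against the limit (the limit of > 40000 nM in this assay, at which 1 of the 3 values shown sits), and its floor lies within the scatter.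

Compound 4 `N#Cc1c(N)cccc1Sc1ccccc1Br` differs from compound 3 by bromo in place of chloro on an aromatic carbon. The measured steps that bear on this position are a 5.1-fold lower number from compound 1 to compound 3 (0.71 log units; beyond the scatter), a modest drop, and an at least 1.2-fold lower number from compound 2 to compound 3 (0.08 log units; that floor lies within the scatter), which barely separates chloro from methyl. An exchange of one halogen for another is a smaller change than either, so the step of a 1.3-fold lower number from compound 3 to compound 4 (0.12 log units; within the scatter) is expected to stay within the scatter, leaning slightly toward a lower number. Compound 4 is estimated at 25000 nM, with a range from 10000 nM to 60000 nM, an expectation resting on compound 3 and its value 33000 nM.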

Compound 4, half-maximal inhibitory concentration: 41000 nM
For compound 4 the middle estimate is 1.6-fold (0.21 log units) below the measured one, and the stated range covers the measured number.
By their numbers in this assay, from the lowest: compounds 3 and 4 (each within the scatter of the next); then compound 1.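

In this assay the exchange of chloro for bromo on this aromatic carbon, ortho to a large group, does not separate the two halogens (a 1.2-fold higher number from compound 3 to compound 4 (0.09 log units; within the scatter)). Bromo in place of hydrogen (a 4.1-fold lower number from compound 1 to compound 4 (0.61 log units; beyond the scatter)) lies beyond the scatter, as chloro in place of hydrogen does (a 5.1-fold lower number from compound 1 to compound 3 (0.71 log units; beyond the scatter)), so among the compounds with readable numbers, both halogens stand apart from hydrogen in the same direction. Compound 2 carries a limit and not a number, and its step to compound 4 cannot be read: the limit of > 40000 nM in this assay, at which 1 of the 4 values shown sits.

On these data alone, whether methyl belongs with the two halogens therefore stays open. Also open, as far as these compounds go, is what fluoro, a methoxy group, a trifluoromethyl group or a carboxylic acid would give at this place.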